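Swapping the aryl group of compound 2 for 4-ethoxyphenyl

The source may report more compounds than this note shows. Statements on the series, on what has been measured and on what is new or still open speak of the compounds shown alone.

Measured in a functional assay on HT-29 cells (Homo sapiens) for inhibition, read by sulforhodamine B assay, with a stated time of 72 h (a higher number here means a weaker inhibitor, a lower number a stronger inhibitor), so far:
- compound 1 `CCSc1ccc(C2C(O)C(=O)N2c2cc(OC)c(OC)c(OC)c2)cc1` gives 12 nM
- compound 2 `COc1ccc(C2C(O)C(=O)N2c2cc(OC)c(OC)c(OC)c2)cc1O` gives 463 nM

Compound 2 stands highest of the two numbers in this assay and compound 1 is its nearest and only neighbour. The next structure is compound 3 `CCOc1ccc(C2C(O)C(=O)N2c2cc(OC)c(OC)c(OC)c2)cc1` with this change from compound 2: 4-ethoxyphenyl in place of 3-hydroxy-4-methoxyphenyl on a saturated ring carbon at the same saturated ring carbon of the four-membered ring.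

Among the compounds with values here, one measured step bears on this change. It is a 39-fold higher number from compound 1 to compound 2 (1.59 log units; beyond the scatter) and it is large, with 3-hydroxy-4-methoxyphenyl in place of 4-(ethylsulfanyl)phenyl at that same ring carbon. Compound 3 gives up the same 3-hydroxy-4-methoxyphenyl, so part of that step may be recovered. Within the data shown here, no compound with 4-ethoxyphenyl has been measured, and a single step is thin evidence, so only partial recovery is assumed. A move to a lower number is expected, estimated as a 7.7-fold lower number from compound 2 to compound 3 (0.89 log units; beyond the scatter) in size. For compound 3 the expected value is 60 nM with an estimated range of 12 nM to 300 nM as the likely span.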

Compound 3, half-maximal inhibitory concentration: 15 nM
Estimate against measurement, compound 3: 4.0-fold (0.60 log units) above; measured number inside the range.
By their numbers in this assay, from the lowest: compounds 1 and 3 (each within the scatter of the next); then compound 2.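

In this assay, 4-ethoxyphenyl in place of 3-hydroxy-4-methoxyphenyl on the saturated ring carbon gives a 31-fold lower number from compound 2 to compound 3 (1.49 log units; beyond the scatter), so a second aryl group now separates from compound 2 by a large step, and the low number at this position is no longer tied to 4-(ethylsulfanyl)phenyl alone. Ethoxy in place of ethylsulfanyl on an aromatic carbon gives a 1.3-fold higher number from compound 1 to compound 3 (0.10 log units; within the scatter), within the scatter, so this pair does not distinguish the two groups, and compound 2 stands apart from both with the weakest number of the three. No measurement on hand accounts for either step.

The step from compound 2 changes two things on the aryl ring at once, so the compounds shown do not separate the contribution of the hydroxy group from that of methoxy against ethoxy, a question that 4-methoxyphenyl at the same ring carbon would address directly. As far as these compounds go, how far this position tolerates other groups also stays open, for example 4-propoxyphenyl with its longer chain or 4-aminophenyl with an amine in place of the ether oxygen.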